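Isopropyl for Methyl on the Aryl Ring of Compound 2

The source may report more compounds than this note shows. Statements on the series, on what has been measured and on what is new or still open speak of the compounds shown alone.

Compound 2 `Cc1ccccc1-n1nc(C)c2c1NC(=O)[C@H](C)S[C@@H]2c1ccc(Oc2ccccc2)cc1` gives 1300 nM in an assay on isolated protein for agonist activity at Bile acid receptor (Homo sapiens), read by AlphaScreen, with a stated time of 30 min; on this read-out lower numbers stand for an effect already at smaller amounts and higher numbers for an effect only at larger amounts of compound. Among the compounds with values here, it is one of only two compounds with a reported number; compound 1 `Cc1ccccc1-n1nc(C)c2c1NC(=O)[C@H](C)S[C@@H]2c1ccc(-c2ccccc2)cc1` gives 990 nM, and the step of a 1.3-fold higher number from compound 1 to compound 2 (0.12 log units; within the scatter) lies within the scatter, so the two are not distinguishable. Compound 3 `Cc1ccccc1-n1nc(C)c2c1NC(=O)[C@H](C)S[C@@H]2c1ccc(Oc2ccccc2C(=O)O)cc1` is reported as "not active" (no number reported) in this assay, without a number. Compound 4 `Cc1nn(-c2ccccc2C(C)C)c2c1[C@@H](c1ccc(Oc3ccccc3)cc1)S[C@@H](C)C(=O)N2` differs from compound 2 by isopropyl in place of methyl on an aromatic carbon. Within the data shown here, no measured step involves this change; the single measured step concerns a different part of the molecule and was itself within the scatter. Compound 4 is therefore expected to show no step beyond the scatter in this assay, no change at the digits printed from compound 2 to compound 4 (within the scatter). Compound 4 is estimated at 1300 nM, with a range of 450 nM to 3800 nM.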

Compound 4, half-maximal effective concentration: 1900 nM
Compound 4: the middle estimate sits 1.5-fold (0.16 log units) below what was measured; the measured number falls inside the stated range.
By their numbers in this assay, from the lowest: compounds 1, 2 and 4 (each within the scatter of the next).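

In this assay, isopropyl in place of methyl on an aromatic carbon, ortho to a large group, gives a 1.5-fold higher number from compound 2 to compound 4 (0.16 log units; within the scatter). Within the data shown here, this is the first measured step at this position, and it shows that the aryl ring can carry isopropyl as well as methyl there without a step beyond the scatter. No independent evidence bears on this result.

From the compounds shown here alone, whether an amine or a longer chain such as n-butyl at this position would behave the same way remains open. Going by these compounds, it is also open whether isopropyl would give a similar result on the core of compound 1.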